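What One Chloro May Do to Clearance

The compounds below may be only part of what the source reports. "The series", "measured", "known", "first", "only" and "open" are said of these compounds alone.

In an ADME assay (liver) for metabolic stability, with Liver microsome (Homo sapiens) as the target, read by LC-MS, using microsomes and NADPH, with a stated time of 5 min, at 37 degrees C (on this read-out lower numbers stand for slow clearance and higher numbers for fast clearance), compound 1 `CCn1c([C@@H](C)NS(=O)(=O)c2ccc(Cl)cc2)nc2cc(C(N)=O)ccc21` gives < 5 mL.min-1.g-1, which is a limit of the assay and not a number. Among the measured compounds shown here, compound 2 `CCn1c([C@@H](C)NS(=O)(=O)c2ccccc2)nc2ccc(C(F)(F)F)cc21` gives 14 mL.min-1.g-1, the only true number so far. Compound 3 `CCn1c([C@@H](C)NS(=O)(=O)c2cccc(Cl)c2)nc2ccc(C(F)(F)F)cc21` differs from compound 2 in one place: chloro in place of hydrogen on an aromatic carbon, with chloro in place of hydrogen on an aromatic carbon, meta to a large group. For the measured compounds named here, no measured pair yet shows what such a change does here. A small rise in clearance is expected, an estimated step of a 1.4-fold higher number from compound 2 to compound 3 (0.15 log units; within the scatter), which may stay close to the usual scatter. For compound 3 the estimate is 20 mL.min-1.g-1, with an expected range of 10 mL.min-1.g-1 to 40 mL.min-1.g-1.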

Compound 3, intrinsic clearance in microsomes: > 100 mL.min-1.g-1
Compound 3 ended at the assay's limit; the forecaster's own chance of this, stated with the estimate: 3%; middle value at least 5.0-fold (0.69 log units) from the limit.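

In this assay a single chloro on this six-membered aromatic ring gives an at least 7.1-fold higher number from compound 2 to compound 3 (0.85 log units; beyond the scatter) and so is far from a small change here. Compound 3 gives > 100 mL.min-1.g-1 as a limit of the assay and not a number. On these data alone, the full size of the step stays unknown because compound 3 sits at that limit: the limit of > 100 mL.min-1.g-1 in this assay, at which 1 of the 3 values shown sits.

As far as these compounds go, whether a fluoro, a methoxy or an amine in the same place would raise clearance this far stays open. These compounds also cannot tell why chloro has this effect here.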